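Cytotoxicity in HeLa cells: chloro to cyano on the distal ring

A few compounds are considered here, and "the series" means these few. Any claim that something is new, unique, unknown or untested is made for them only; others in the source may bear on it.

Within the data shown here, compound 2 `COc1cc(CC(O)c2ccc(-c3ccc(Cl)cc3)cc2)c([N+](=O)[O-])cc1OC` holds the lowest of the two numbers so far in an ADME assay on HeLa Rh cells (Homo sapiens) for cytotoxicity, read by microscopy (on this read-out higher numbers stand for lower toxicity in this test and lower numbers for higher toxicity in this test), where compound 2 gives 4100 nM. Its nearest neighbour, compound 1 `COc1cc(CC(O)c2ccc(-c3ccc([N+](=O)[O-])cc3)cc2)c([N+](=O)[O-])cc1OC`, gives 21000 nM in this assay; the change to compound 2 was a single substitution, chloro in place of nitro on an aromatic carbon, and gave a 5.1-fold lower number from compound 1 to compound 2 (0.71 log units; beyond the scatter).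

Compound 3 `COc1cc(CC(O)c2ccc(-c3cccc(C#N)c3)cc2)c([N+](=O)[O-])cc1OC` differs from compound 2 by 3-cyanophenyl in place of 4-chlorophenyl on an aromatic carbon. Among the measured compounds shown here, no measured step covers this particular exchange; the only step in hand, from compound 1 to compound 2, concerns the same outer ring but a different pair of groups, so it gives direction only loosely. A step within the scatter, or at most a modest rise, is the expectation for compound 3, so that compound 3 is estimated at 7000 nM, with a range of 2500 nM to 25000 nM, corresponding to an expected step of a 1.7-fold higher number from compound 2 to compound 3 (0.23 log units; within the scatter).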

Compound 3, half-maximal cytotoxic concentration: 5200 nM
For compound 3 the middle estimate is 1.3-fold (0.13 log units) above the measured one, and the stated range covers the measured number.
By their numbers in this assay, from the lowest: compounds 2 and 3 (each within the scatter of the next); then compound 1.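

In this assay the exchange of 4-chlorophenyl for 3-cyanophenyl gives a 1.3-fold higher number from compound 2 to compound 3 (0.10 log units; within the scatter) and leaves the two compounds inseparable, even though the outer ring carries a different group under a different name. Set against the 4-nitrophenyl group, 3-cyanophenyl gives a 4.0-fold lower number from compound 1 to compound 3 (0.61 log units; beyond the scatter) and thus, like 4-chlorophenyl, lies beyond the scatter, so compound 1 stands apart from compound 2 and compound 3, with none of the three going against this. Nothing on hand bears on the reason for these numbers.

Group and ring place change together between compound 2 and compound 3, so the nitrile and its place on the ring cannot be read separately. As far as these compounds go, whether an amine or a carboxylic acid on this outer ring would fall with compound 2 and compound 3 or with compound 1 remains open.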